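Swapping methoxy for fluoro on an aromatic carbon

The source may hold more compounds than are shown below. What is called first, only, known or untested is meant among the compounds shown, and "the series" means these compounds.

Compound 1, `Cn1c(=O)cnn(CCCCN2CCN(c3cccc(F)n3)CC2)c1=O`, in an assay for displacement of a labelled ligand from Adrenergic receptor alpha-1 (Homo sapiens) (a lower number here means a stronger inhibitor, a higher number a weaker inhibitor), gives > 10000 nM, a limit of the assay rather than a number.
Compound 2, `Cn1c(=O)cnn(CCCCN2CCN(c3cccc(Br)n3)CC2)c1=O`, gives > 10000 nM, also a limit.
Compound 3, `COc1ccccc1N1CCN(CCCn2ncc(=O)n(C)c2=O)CC1`, gives > 10000 nM, again a limit.

All three measured compounds share a core and none of them returns a number in this assay: every value is a limit, as the limit of > 10000 nM in this assay, at which 3 of the 3 values shown sit, records. Compound 3 therefore stands at that limit, with no measured number that would place it relative to compound 1 or compound 2. Among the measured compounds shown here, the single step between two measured compounds that differ in one place, a step that the two limits leave unreadable from compound 1 to compound 2, has a limit at each of its ends and gives no size at all.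

Compound 4, `Cn1c(=O)cnn(CCCN2CCN(c3ccccc3F)CC2)c1=O`, differs from compound 3 by fluoro in place of methoxy on an aromatic carbon. For the measured compounds named here, no measured step covers this exchange, and the one step on record carries no readable size, so there is nothing to set a direction or a magnitude. The expected step is a step that the limit leaves unreadable from compound 3 to compound 4, which means nothing beyond the scatter, with a strong chance that compound 4 too returns only a limit. Compound 4 is estimated at 15000 nM, within a range from 3000 nM to 60000 nM.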

Compound 4, inhibition constant: > 10000 nM
Compound 4: a limit, no number (the forecaster's own chance of this, stated with the estimate: 75%); the middle value is on the limit's open side.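

In this assay compound 4 gives > 10000 nM, a limit of the assay and not a number. Among the compounds shown here, compound 3 also sits at a limit, so no step from compound 3 to compound 4 can be read, for fluoro in place of methoxy or in size. All four compounds rest at the same boundary: the limit of > 10000 nM in this assay, at which 4 of the 4 values shown sit.

From the compounds shown here alone, how strong an inhibitor any of the four compounds is remains open, as does which change, if any, would bring a measurable number.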